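Side-chain swap from compound 1 to compound 3

A few compounds are considered here, and "the series" means these few. Any claim that something is new, unique, unknown or untested is made for them only; others in the source may bear on it.

In an in vitro ADME assay on microsomes from liver (Homo sapiens) for metabolic stability (a lower number here means that the compound disappears faster, a higher number that the compound lasts longer), compound 1 (`C[C@@H](c1ccc(Cl)cc1)N1Cc2cncn2C(CC2(C)COC2)S1(=O)=O`) gives 1.27 h and stands highest of the two measured compounds. Compound 2 (`CC(C)CC1n2cncc2CN(Cc2ccccc2)S1(=O)=O`) gives 0.05 h and differs from compound 1 in more than one place, so this pair isolates no single change. The gap between these two compounds lies beyond the scatter. Compound 3 (`C[C@@H](c1ccc(Cl)cc1)N1Cc2cncn2C(C[C@@H](O)c2ccccc2)S1(=O)=O`) is not yet measured. It carries hydroxy(phenyl)methyl in place of 3-methyloxetan-3-yl on a saturated chain carbon bound to a saturated ring carbon. Going by the values given here, no measured step covers this change, so the expectation in this assay is a judgement only: a fall from the high starting point of compound 1 (1.27 h). The expected step is a 3.2-fold lower number from compound 1 to compound 3 (0.50 log units; beyond the scatter) and carries wide uncertainty. For compound 3 the estimated half-life is 0.4 h (expected range 0.12 h to 1.3 h).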

Compound 3, half-life: 0.4 h
Compound 3: middle estimate and measured number agree at the digits printed, and the stated range covers the measured number.
By their numbers in this assay, from the lowest: compound 2; then compound 3; then compound 1.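

In this assay, going by these compounds alone, the swap of 3-methyloxetan-3-yl for hydroxy(phenyl)methyl on a saturated chain carbon bound to a saturated ring carbon gives a 3.2-fold lower number from compound 1 to compound 3 (0.50 log units; beyond the scatter) and is the only single-place reading. The half-life therefore responds to the group at this position, which the comparison of compound 1 with compound 2 could not isolate. The change removes a four-membered non-aromatic ring and brings in a six-membered aromatic ring of carbon only, a hydrogen-bond donor and a defined stereocentre, and nothing at hand explains the step or assigns it to any one of these features.

The compounds shown do not separate the hydroxy group from the phenyl ring, nor show how the opposite configuration at the hydroxy-bearing carbon compares. On these data alone, how a plain 2-phenylethyl chain or a carboxylic acid at this position would behave also stays open.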